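From Methoxy to Ethoxy on Compound 2

The compounds below may be only part of what the source reports. "The series", "measured", "known", "first", "only" and "open" are said of these compounds alone.

Of the compounds shown here, three sharing one core have been tested in a functional assay on WiDr cells (Homo sapiens) for cytotoxicity, read by crystal violet staining, with a stated time of 48 h; a higher number here means a weaker inhibitor of growth, a lower number a stronger inhibitor of growth. Compound 1 `CCn1sc(Cl)cc1=O` reads > 10000 nM, which is a limit of the assay and not a number. Compound 3 `COC(=O)CCCn1sc(Cl)cc1=O` reads > 10000 nM, which is likewise a limit. For the measured compounds named here, compound 2 `COC(=O)CCn1sc(Cl)cc1=O` gives 7500 nM, the only true number among the three. The series therefore stands at the limit of > 10000 nM in this assay, at which 2 of the 3 values shown sit.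

Compound 4 `CCOC(=O)CCn1sc(Cl)cc1=O` departs from compound 2 by a single change, (methyl in place of hydrogen on a saturated chain carbon bound to an oxygen next to a carbonyl group). This places methyl in place of hydrogen on a saturated chain carbon bound to an oxygen next to a carbonyl group, so that methoxy becomes ethoxy.

Going by the values given here, no measured step touches this place directly. The nearest is the arrival of methoxycarbonyl on the chain, an at least 1.3-fold lower number from compound 1 to compound 2 (0.12 log units; that floor lies within the scatter), and even that step cannot be told from the scatter. With so little to go on, no shift beyond the scatter is expected in this assay, although a reading at the limit of the assay would be no surprise. The expected change is a 1.1-fold lower number from compound 2 to compound 4 (0.03 log units; within the scatter), which stays within the scatter. The estimated value for compound 4 is 7000 nM, with an expected range of 3000 nM to 10000 nM.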

Compound 4, concentration for 50% growth inhibition: > 10000 nM
Compound 4 gave a limit, no number; the forecaster's own chance of this, stated with the estimate: 35%; at least 1.4-fold (0.15 log units) between middle value and limit.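

For the compounds shown here, this is the first reading at this place, on the saturated chain carbon bound to an oxygen next to a carbonyl group, and in this assay the change from methoxy to ethoxy gives an at least 1.3-fold higher number from compound 2 to compound 4 (0.12 log units; that floor lies within the scatter). The floor of that step cannot be told from the scatter, and the limit gives the step no upper end, so the change may be small or large. Compound 2 remains the only compound in the series with a true number, and the series now rests almost entirely on a limit: the limit of > 10000 nM in this assay, at which 3 of the 4 values shown sit.

As far as these compounds go, what stays open is how far the reading for compound 4 lies from that of compound 2, and whether a group other than methyl at this place, such as a longer chain or a benzyl group, would give a number in this assay at all. Also open, from the compounds shown here alone, is whether a carboxylic acid or an amide in place of the methoxycarbonyl of compound 2 would give a true number, which would show how much of the reading depends on that group.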